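The source may hold more compounds than are shown below. What is called first, only, known or untested is meant among the compounds shown, and "the series" means these compounds.

All three measured compounds were tested in a functional assay on HBL-100 cells (Homo sapiens) for inhibition, read by sulforhodamine B assay, with a stated time of 48 h; a lower number here means a stronger inhibitor of growth, a higher number a weaker inhibitor of growth:

Compound 1, `COC(=O)[C@@]1(C)CCC=C2[C@@H]1CC[C@@H](C)[C@]2(C)Cc1c[nH]c2ccc(F)cc12`, gives 4800 nM.
Compound 2, `COC(=O)[C@@]1(C)CCC=C2[C@@H]1CC[C@@H](C)[C@]2(C)Cc1c[nH]c2c(Cl)cccc12`, gives 19000 nM.
Compound 3, `COC(=O)[C@@]1(C)CCC=C2[C@@H]1CC[C@@H](C)[C@]2(C)Cc1c(C)[nH]c2ccc(C)cc12`, gives 25000 nM.

Compound 3 has the highest of the three numbers. Its number sits within the usual scatter of the number for compound 2, so those two cannot be told apart on these data. Compound 1, by contrast, has a clearly lower number, beyond the scatter, so compound 1 inhibits the growth of these cells more strongly than compound 3 does.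

Compound 4, `COC(=O)[C@@]1(C)CCC=C2[C@@H]1CC[C@@H](C)[C@]2(C)Cc1c(C)[nH]c2ccc(C(F)(F)F)cc12`, has not yet been measured. It differs from compound 3 in one place: trifluoromethyl in place of methyl on an aromatic carbon. Among the measured compounds shown here, no pair of measured compounds shows what this particular exchange does, and the three measured compounds differ from one another in several places at once, so there is no measured step to lean on. The expectation is therefore cautious: a step in this assay of no more than the usual scatter, in either direction. Compound 4 is estimated at 20000 nM, within a range from 7000 nM to 60000 nM, which means an expected step of a 1.3-fold lower number from compound 3 to compound 4 (0.10 log units; within the scatter).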

Compound 4, concentration for 50% growth inhibition: 16000 nM
For compound 4 the middle estimate is 1.3-fold (0.10 log units) above the measured one, and the stated range covers the measured number.
By their numbers in this assay, from the lowest: compound 1; then compounds 4, 2 and 3 (each within the scatter of the next).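

In this assay putting trifluoromethyl in place of methyl on this aromatic carbon gives a 1.6-fold lower number from compound 3 to compound 4 (0.19 log units; within the scatter) so the two compounds cannot be told apart. Among the compounds shown here, this is the first exchange at this position that can be read on its own, since the earlier compounds differ from one another in several places at once. It shows that replacing a group of 1 heavy atom with one of 4 heavy atoms here does not move the number beyond the scatter, and no measurement at hand explains why.

The compounds shown leave open whether a different group on this same carbon, such as an amine, a carboxylic acid or a longer chain, would give a number clearly apart from that of compound 3. They also leave open whether the same exchange on another carbon of this ring would give a similar step.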